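A few compounds are considered here, and "the series" means these few. Any claim that something is new, unique, unknown or untested is made for them only; others in the source may bear on it.

Measured in an ADME assay on MT4 cells (Homo sapiens) for cytotoxicity, read by MTT assay, with a stated time of 5 days; on this read-out lower numbers stand for higher toxicity in this test and higher numbers for lower toxicity in this test:
compound 1 `N#Cc1ccc(Nc2nccc(OCc3ccccc3Cl)n2)cc1` — 146000 nM
compound 2 `N#Cc1ccc(Nc2nccc(OCc3cccnc3)n2)cc1` — 6400 nM
compound 3 `N#Cc1ccc(Nc2nccc(OCc3ccc(Cl)cc3)n2)cc1` — 156000 nM

Compound 3 gives the highest number of the three; compound 1 sits close to it and compound 2 lies far below. The step of a 1.1-fold higher number from compound 1 to compound 3 (0.03 log units; within the scatter) is within the scatter, whereas the step of a 24-fold higher number from compound 2 to compound 3 (1.39 log units; beyond the scatter) is large.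

Compound 4 `COc1ccc(COc2ccnc(Nc3ccc(C#N)cc3)n2)cc1` differs from compound 3 by methoxy in place of chloro on an aromatic carbon. Among the measured compounds shown here, no measured step exchanges chloro for methoxy. For the measured compounds named here, the one change that keeps a carbon-only ring, a 1.1-fold higher number from compound 1 to compound 3 (0.03 log units; within the scatter), is small, while the large step of a 24-fold higher number from compound 2 to compound 3 (1.39 log units; beyond the scatter) concerns the ring itself, which compound 4 retains. A step within the scatter in this assay is therefore expected, leaning somewhat lower. Compound 4 is estimated at 120000 nM (range 50000 nM to 250000 nM), the expected step being a 1.3-fold lower number from compound 3 to compound 4 (0.11 log units; within the scatter).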

Compound 4, half-maximal cytotoxic concentration: 102000 nM
For compound 4 the middle estimate is 1.2-fold (0.07 log units) above the measured one; the range from low to high includes it.
By their numbers in this assay, from the lowest: compound 2; then compounds 4, 1 and 3 (each within the scatter of the next).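

In this assay, methoxy in place of chloro on an aromatic carbon para to a large group gives a 1.5-fold lower number from compound 3 to compound 4 (0.18 log units; within the scatter) and so leaves the read-out unchanged within the scatter. Likewise, a 1.4-fold lower number from compound 1 to compound 4 (0.16 log units; within the scatter) shows that 4-methoxyphenyl matches 2-chlorophenyl within the scatter, whereas a 16-fold higher number from compound 2 to compound 4 (1.20 log units; beyond the scatter) keeps the pyridin-3-yl compound apart from the three carbon-only rings. From the compounds shown here alone, whether an amine or a carboxylic acid at this para place would also hold the number remains open, as does whether other nitrogen-bearing rings follow pyridin-3-yl. No measurement bearing on the origin of these steps is available.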